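The source may hold more compounds than are shown below. What is called first, only, known or untested is meant among the compounds shown, and "the series" means these compounds.

Among the measured compounds shown here, in a functional assay on the whole organism for positive allosteric modulation, with Mus musculus as the target (on this read-out higher numbers stand for an effect only at larger amounts of compound and lower numbers for an effect already at smaller amounts), compound 1 `CCC(=O)N(c1ccc(Cl)c(Cl)c1)C1CCCC1O` gives 0.4 mg/kg and compound 2 `C=CCNC1CCCC1N(C(=O)CC)c1ccc(Cl)c(Cl)c1` gives 0.2 mg/kg, so compound 2 stands within the scatter of the only other measured compound. Compound 3 `CCC(=O)N(c1ccc(Cl)c(Cl)c1)C1CCCC1N(C)Cc1ccccc1` differs from compound 2 by benzyl(methyl)amino in place of allylamino on a saturated ring carbon, with benzyl(methyl)amino in place of allylamino on a saturated ring carbon. For the measured compounds named here, the one measured step that bears on this change, also on a saturated ring carbon, is a 2.0-fold lower number from compound 1 to compound 2 (0.30 log units; within the scatter). That single step gives no reason to expect a change beyond the scatter in this assay. The expected size is a 1.5-fold higher number from compound 2 to compound 3 (0.18 log units; within the scatter). For compound 3 the estimated value is 0.3 mg/kg, with an expected range of 0.08 mg/kg to 1.2 mg/kg.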

Compound 3, dose for half-maximal effect: 0.2 mg/kg
For compound 3 the middle estimate is 1.5-fold (0.18 log units) above the measured one; the measured number falls inside the stated range.
By their numbers in this assay, from the lowest: compounds 2, 3 and 1 (each within the scatter of the next).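

In this assay, the saturated ring carbon takes benzyl(methyl)amino, which brings a six-membered aromatic ring and has no hydrogen-bond donor, with no shift beyond the scatter relative to allylamino (no change at the digits printed from compound 2 to compound 3 (within the scatter)) or hydroxy (a 2.0-fold lower number from compound 1 to compound 3 (0.30 log units; within the scatter)). At this position, a group of nine heavy atoms without a donor therefore reads the same as the smaller groups. Nothing measured here explains this result. On these data alone, whether a carboxylic acid or a longer alkyl chain on this carbon would move the number beyond the scatter remains open.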